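Swapping the Aryl Ring in a Dopamine Receptor Oxime Series

This account rests on a few compounds, and the source may have more. Where it says the series, first, only, none or still open, it means among the compounds named here.

Measured compounds in a functional assay on HEK293 cells with D(4) dopamine receptor (Homo sapiens) as the target, read by FLIPR; on this read-out lower numbers stand for smaller maximal responses and higher numbers for larger maximal responses:
compound 1, `O/N=C(/CCN1CCN(c2ccccn2)CC1)c1ccccc1`, 74%
compound 2, `Cc1ccccc1/C(CCN1CCN(c2ccccn2)CC1)=N\O`, 72%
compound 3, `O/N=C(\CCN1CCN(c2ccccn2)CC1)c1cccc(Cl)c1`, 73%

Compound 3 stands second highest of the three numbers, but compound 1 and compound 2 both lie within the usual scatter of it, so no order can be read among the three. Within the data shown here, the one step that can be followed between single-change neighbours, a number 2 percentage points lower from compound 1 to compound 2 (within the scatter), also stayed within the scatter; it changed a substituent on the aromatic ring attached to the oxime carbon, which is the same part of the shared core that is varied next.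

Compound 4 is `O/N=C(\CCN1CCN(c2ccccn2)CC1)c1ccc(F)cc1F`. It differs from compound 3 in one place: 2,4-difluorophenyl in place of 3-chlorophenyl on a carbon with a double bond to nitrogen. Among the measured compounds shown here, since the only comparable step was flat, and all three measured values sit together, no change beyond the scatter is expected in this assay for compound 4; the expected step is no change at the digits printed from compound 3 to compound 4 (within the scatter). Compound 4 is therefore estimated at 73%, in a range from 60% to 85%.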

Compound 4, largest response reached (reported as efficacy), in percent of the reference or control that the assay uses: 78%
Estimate against measurement, compound 4: 5 percentage points below; measured number inside the range.
By their numbers in this assay, from the lowest: compounds 2, 3, 1 and 4 (each within the scatter of the next).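

In this assay the step of a number 5 percentage points higher from compound 3 to compound 4 (within the scatter) replaces the whole substituted aryl group on the carbon with a double bond to nitrogen, with 2,4-difluorophenyl entering for 3-chlorophenyl. The earlier step of a number 2 percentage points lower from compound 1 to compound 2 (within the scatter) added only a methyl, so this result extends the flat picture at this position to a change of both halogen and substitution pattern, and this larger exchange also stays within the scatter. Nothing available here bears on why the number stays within the scatter for this change.

The aryl groups shown carry only methyl, chlorine or fluorine, so it remains open whether an amine or a carboxylic acid on that ring would move the maximal response beyond the scatter. Going by these compounds, it also remains open what a longer chain in place of the saturated chain of the shared core would do.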